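Acid in place of ester: compound 2 to compound 3

A few compounds are considered here, and "the series" means these few. Any claim that something is new, unique, unknown or untested is made for them only; others in the source may bear on it.

Compound 2 `CC#CCn1c(N2CCC[C@@H](N)C2)nc2c1c(=O)n(Cc1ccccc1C(=O)OC)c(=O)n2C` is one of two members of the series measured so far. In an ADME assay on isolated protein for inhibition of Dipeptidyl peptidase 9 (Homo sapiens), with stated times of 15 min, 60 s and 20 min (on this read-out lower numbers stand for stronger inhibition and higher numbers for weaker inhibition), compound 2 reaches only the limit of the assay, > 100000 nM, so it has no number of its own. Compound 1 `CC#CCn1c(N2CCC[C@@H](N)C2)nc2c1c(=O)n(Cc1ccc(Br)cc1C(=O)OCC)c(=O)n2C` is the other measured member, and in this assay compound 1 also returns a limit, > 100000 nM. Going by the values given here, both values sit at the limit of > 100000 nM in this assay, at which 2 of the 2 values shown sit, and the single step between them, a step that the two limits leave unreadable from compound 1 to compound 2, is therefore unreadable in size and direction.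

Compound 3 `CC#CCn1c(N2CCC[C@@H](N)C2)nc2c1c(=O)n(Cc1cc(OC)ccc1C(=O)O)c(=O)n2C` differs from compound 2 in one place: 2-carboxy-5-methoxyphenyl in place of 2-(methoxycarbonyl)phenyl on a saturated chain carbon bound to an aromatic nitrogen. Among the compounds with values here, no measured step bears on this change; the only step on record is the unreadable one just described, so no size can be drawn from it.

For compound 3 in this assay, a value at or beyond the same limit is expected, estimated at 150000 nM with a range of 50000 nM to 500000 nM. The expected step that the limit leaves unreadable from compound 2 to compound 3 is thus an estimate of no change beyond the scatter.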

Compound 3, half-maximal inhibitory concentration: > 100000 nM
Compound 3: only a limit was reported; the forecaster's own chance of this, stated with the estimate: 85%; the middle value is on the limit's open side.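

In this assay compound 3 gives > 100000 nM, a limit of the assay and not a number. The steps linking compound 3 to compound 1 and compound 2 therefore cannot be read: the limit of > 100000 nM in this assay, at which 3 of the 3 values shown sit.

The compounds shown leave open how far compound 1, compound 2 and compound 3 differ, and whether any group on this saturated chain carbon bound to an aromatic nitrogen gives a readable value.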